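The compounds below may be only part of what the source reports. "The series", "measured", "known", "first", "only" and "open" are said of these compounds alone.

Going by the values given here, compound 2 `CCCn1cc(S(=O)(=O)c2ccc(CNC(=O)N3Cc4ccncc4C3)cc2)cn1` gives 11 mL/min/kg in an ADME assay on microsomes from liver (Homo sapiens) for pharmacokinetics, read by LC-MS, with a stated time of 60 min, tested at 1 uM (a higher number here means faster removal of the compound, a lower number slower removal), the lowest of the two numbers measured so far. Compound 1 `O=C(NCc1ccc(S(=O)(=O)c2cccc(C(F)(F)F)c2)cc1)N1Cc2ccncc2C1` gives 14 mL/min/kg, and the step of a 1.3-fold lower number from compound 1 to compound 2 (0.10 log units; within the scatter) swapped the group on the sulfonyl sulfur without moving the number beyond the scatter. Compound 3 `O=C(NCc1ccc(S(=O)(=O)C2CCOCC2)cc1)N1Cc2ccncc2C1` changes that same position again: oxan-4-yl in place of 1-propyl-1H-pyrazol-4-yl on a sulfonyl sulfur. Among the compounds with values here, since the one comparable step stayed within the scatter, no clear shift is expected, and the estimated step is a 1.1-fold higher number from compound 2 to compound 3 (0.04 log units; within the scatter). For compound 3 the expected value is 12 mL/min/kg, with a range from 6 mL/min/kg to 24 mL/min/kg.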

Compound 3, clearance: 6 mL/min/kg
For compound 3 the middle estimate is 2.0-fold (0.30 log units) above the measured one; the measured number falls inside the stated range.
By their numbers in this assay, from the lowest: compounds 3, 2 and 1 (each within the scatter of the next, the first and the last beyond it).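

Going by these compounds alone, with oxan-4-yl, a non-aromatic ring sits on the sulfonyl sulfur for the first time. Within the data shown here, in place of 1-propyl-1H-pyrazol-4-yl it gives a 1.8-fold lower number from compound 2 to compound 3 (0.26 log units; within the scatter), but in place of 3-(trifluoromethyl)phenyl it gives a 2.3-fold lower number from compound 1 to compound 3 (0.37 log units; beyond the scatter), the first step at this position to pass the scatter, though only modestly. Nothing measured here gives a reason for this result. Cyclohexyl, the same ring without its oxygen, could show whether that oxygen matters. On these data alone, whether piperidin-4-yl, which carries an amine, or an open butyl chain would give a similar number also remains open.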